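Relocating a hydroxyl on a cytotoxically silent anilino scaffold

The source may hold more compounds than are shown below. What is called first, only, known or untested is meant among the compounds shown, and "the series" means these compounds.

Compound 1, `Fc1cccc(-c2nc(Nc3cccc(Cl)c3)c3cc(F)ccc3n2)c1`, was examined in a functional assay on MDA-MB-231 cells (Homo sapiens) for cytotoxicity, read by MTT assay, with a stated time of 48 h; a higher number here means a weaker inhibitor, a lower number a stronger inhibitor. In this assay compound 1 reaches only the limit of the assay, > 50000 nM. Compound 2, `Oc1ccc(Nc2nc(-c3cccc(F)c3)nc3ccc(F)cc23)cc1`, carries a 4-hydroxyphenyl in place of the 3-chlorophenyl on a nitrogen on an aromatic ring. In this assay compound 2 likewise returns only a limit, > 50000 nM. The step that the two limits leave unreadable from compound 1 to compound 2 is therefore of unknown size, as the limit of > 50000 nM in this assay, at which 2 of the 2 values shown sit, shows both values resting at the same limit. Compound 2 thus stands at the edge of what this assay can report, with no number of its own.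

Compound 3, `Oc1ccccc1Nc1nc(-c2cccc(F)c2)nc2ccc(F)cc12`, differs from compound 2 by 2-hydroxyphenyl in place of 4-hydroxyphenyl on a nitrogen on an aromatic ring. For the measured compounds named here, the only measured step, from compound 1 to compound 2, bears on this change solely in that neither endpoint reached a number, so no direction or size can be read from it. Compound 3 is therefore expected to remain at the limit, with the estimated step that the limit leaves unreadable from compound 2 to compound 3 carrying no weight beyond the scatter. Compound 3 is estimated at 60000 nM, with a range from 25000 nM to 150000 nM.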

Compound 3, half-maximal inhibitory concentration: > 50000 nM
Compound 3: only a limit was reported; the forecaster's own chance of this, stated with the estimate: 75%; the middle value is on the limit's open side.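

Compound 3 joins compound 1 and compound 2 at the same limit, so no step among these three compounds can be read: the limit of > 50000 nM in this assay, at which 3 of the 3 values shown sit.

What the compounds shown leave open is whether any change to the group on the nitrogen of the shared core would give a readable number in this assay.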